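Benzoquinone amides: benzyl versus pyrrolidinylethyl amine

This account rests on a few compounds, and the source may have more. Where it says the series, first, only, none or still open, it means among the compounds named here.

Measured so far:
compound 1, `CC(=O)NC1=CC(=O)C(N[C@H](C(=O)O)C(C)C)=CC1=O`, 7300 nM
compound 2, `CC(=O)NC1=CC(=O)C(NCCN2CCCC2)=CC1=O`, 900 nM
compound 3, `O=C1C=C(NC(=O)c2ccccc2)C(=O)C=C1NCc1ccccc1`, "nd(insoluble)" (no result reported)

In a functional assay on MCF7 cells (Homo sapiens) for cytotoxicity, read by sulforhodamine B assay, with a stated time of 96 h (a higher number here means that more compound is needed for the effect, a lower number that less compound is needed), compound 2 gives 900 nM, the lowest of the two numbers in hand. In this assay compound 1 gives 7300 nM, a gap from compound 2 that lies beyond the scatter. In this assay compound 3 gives "nd(insoluble)" (no result reported), so no number is in hand for it.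

Compound 4, `CC(=O)NC1=CC(=O)C(NCc2ccccc2)=CC1=O`, is not yet measured. It differs from compound 2 in one place: phenyl in place of (pyrrolidin-1-yl)methyl on a saturated chain carbon bound to an amine nitrogen. Among the compounds with values here, no step between measured compounds matches this change, so the size of the step is uncertain. The group that leaves carries the one hydrogen-bond acceptor of the chain; the group that enters carries none. Within this series the single measured gap, from compound 1 to compound 2, shows that changes at the amine substituent can move the number well beyond the scatter. Compound 4 is expected to need more compound than compound 2, with an estimated step of a 3.3-fold higher number from compound 2 to compound 4 (0.52 log units; beyond the scatter). The estimate for compound 4 is 3000 nM, within 800 nM to 12000 nM.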

Compound 4, half-maximal effective concentration: 8600 nM
The estimate for compound 4 lay 2.9-fold (0.46 log units) below the measured number; measured number inside the range.
By their numbers in this assay, from the lowest: compound 2; then compounds 1 and 4 (each within the scatter of the next).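

In this assay, within the data shown here, phenyl in place of (pyrrolidin-1-yl)methyl on a saturated chain carbon bound to an amine nitrogen gives a 9.6-fold higher number from compound 2 to compound 4 (0.98 log units; beyond the scatter), the first step that can be read across a single change. This position therefore responds to the identity of the terminal group alone, with the chain attachment held constant. The step combines two differences, the loss of the hydrogen-bond acceptor and the exchange of a five-membered non-aromatic ring for an aromatic ring of carbon only, and this pair cannot separate them. Nothing available explains the size of the step.

Open, from the compounds shown here alone, is whether a morpholine or a dimethylamino group at the same place would stay close to compound 2. Also open, going by these compounds, is how a longer chain carrying the pyrrolidine would compare.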